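This account rests on a few compounds, and the source may have more. Where it says the series, first, only, none or still open, it means among the compounds named here.

Measured so far:
compound 1 `CC(C(=O)N1CCN(c2ccccc2)CC1)N1C(=O)CCC1=O` — 50%
compound 2 `CC(C(=O)N1CCN(c2ccccc2F)CC1)N1C(=O)CCC1=O` — 50%

In a functional assay on the whole organism (strain Swiss) with Mus musculus as the target, in the maximal electroshock model, with a stated time of 1 h, at a dose of 300 mg/kg by the intraperitoneal route (a higher number here means a stronger effect of the compound at the dose given, a lower number a weaker effect), compound 1 gives 50% and compound 2 gives 50%. Within the data shown here, the only measured step, no change at the digits printed from compound 1 to compound 2 (within the scatter), leaves the read-out where it was. Compound 2 thus stands level with compound 1 at the digits shown.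

Compound 3 `CC(C(=O)N1CCN(c2ccccc2C(F)(F)F)CC1)N1C(=O)CCC1=O` differs from compound 2 by trifluoromethyl in place of fluoro on an aromatic carbon. Among the measured compounds shown here, the one measured step touches the same aromatic position, and it showed no change beyond the scatter; nothing measured speaks to the larger group. On that basis the step of no change at the digits printed from compound 2 to compound 3 (within the scatter) is expected to be small, with no direction beyond the scatter. Compound 3 is therefore estimated at 50%, expected within 25% to 75%.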

Compound 3, a percentage reported as activity, at one dose (the size of the read-out at that dose, not a potency): 75%
Compound 3: middle estimate off by 25 percentage points, on the low side; the range from low to high includes it.
By their numbers in this assay, from the lowest: compounds 1 and 2 (each within the scatter of the next); then compound 3.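

In this assay, the aromatic carbon ortho to a large group proves sensitive to what it carries: trifluoromethyl gives a number 25 percentage points higher from compound 2 to compound 3 (beyond the scatter), and a number 25 percentage points higher from compound 1 to compound 3 (beyond the scatter). Fluoro alone had not separated from hydrogen, so this position is not indifferent to substitution, although the read-out holds for a single dose only. Nothing available accounts for the gain.

On these data alone, whether trifluoromethyl is specifically required here remains open, as methyl, chloro or methoxy on this carbon would test that. As far as these compounds go, the effect of an amine or a carboxylic acid at this place also remains unknown.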